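This account rests on a few compounds, and the source may have more. Where it says the series, first, only, none or still open, it means among the compounds named here.

Notes on the amide series, read in a functional assay on PC-3 cells (Homo sapiens) for antiproliferative activity, read by MTT assay, with a stated time of 24 h; on this read-out lower numbers stand for stronger inhibition and higher numbers for weaker inhibition. Compound 1 (`CCn1c(C(=O)NCC(=O)OC)ccc1C(CC)(CC)c1ccc(OCS(=O)(=O)c2ccccc2)c(C)c1`) gives > 50000 nM, which is a limit of the assay and not a number. Compound 2 (`CCn1c(C(=O)N[C@@H](CC(=O)OC)C(=O)OC)ccc1C(CC)(CC)c1ccc(OCS(=O)(=O)c2ccccc2)c(C)c1`) gives 6490 nM and compound 3 (`CCn1c(C(=O)NC2(CO)CC2)ccc1C(CC)(CC)c1ccc(OCS(=O)(=O)c2ccccc2)c(C)c1`) gives 3560 nM, and these two values lie within the scatter of each other, with a 1.8-fold lower number from compound 2 to compound 3 (0.26 log units; within the scatter).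

Compound 4 (`CCn1c(C(=O)NCCCO)ccc1C(CC)(CC)c1ccc(OCS(=O)(=O)c2ccccc2)c(C)c1`) carries 3-hydroxypropyl in place of 1-(hydroxymethyl)cyclopropyl on an amide-type nitrogen. The three-membered ring leaves, and the substituent keeps 1 hydrogen-bond donor and 1 hydrogen-bond acceptor.

Two steps at this nitrogen are beyond the scatter: an at least 14-fold lower number from compound 1 to compound 3 (1.14 log units; beyond the scatter) is large, while an at least 7.7-fold lower number from compound 1 to compound 2 (0.88 log units; beyond the scatter) involves a change on the saturated chain carbon. Both start from a limit. Against these, a 1.8-fold lower number from compound 2 to compound 3 (0.26 log units; within the scatter) shows two quite different substituents giving values within the scatter. Among the compounds with values here, no measured step isolates the loss of the ring, so the expectation is no step clearly beyond the scatter, if anything towards a higher number. The expected step is a 1.8-fold higher number from compound 3 to compound 4 (0.26 log units; within the scatter). For compound 4 the estimated value is 6500 nM, with an expected range of 2000 nM to 30000 nM.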

Compound 4, half-maximal inhibitory concentration: 11300 nM
The estimate for compound 4 lay 1.7-fold (0.24 log units) below the measured number; the measured number falls inside the stated range.
By their numbers in this assay, from the lowest: compounds 3, 2 and 4 (each within the scatter of the next, the first and the last beyond it). At a limit, above all of these: compound 1.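

Within the data shown here, replacing 1-(hydroxymethyl)cyclopropyl with 3-hydroxypropyl on the amide-type nitrogen, with hydrogen-bond donors and acceptors unchanged in number, gives a 3.2-fold higher number from compound 3 to compound 4 (0.50 log units; beyond the scatter), so this is the first measured step to show that the substituent on this nitrogen can matter even when those counts stay the same. The 1,2-bis(methoxycarbonyl)ethyl and 3-hydroxypropyl substituents are not separated, with a 1.7-fold higher number from compound 2 to compound 4 (0.24 log units; within the scatter), so two groups that share no obvious resemblance again give values within the scatter. The third step, an at least 4.4-fold lower number from compound 1 to compound 4 (0.64 log units; beyond the scatter), starts from a limit and not a number: the limit of > 50000 nM in this assay, at which 1 of the 4 values shown sits.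

Going by these compounds, whether the loss of the ring itself or the loss of branching on the carbon bound to the nitrogen carries the step from the cyclopropyl compound remains open. On these data alone, how a 4-hydroxybutyl chain, or a carboxylic acid in place of the terminal hydroxyl, would read on this nitrogen also remains open.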